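The source may hold more compounds than are shown below. What is called first, only, known or untested is meant among the compounds shown, and "the series" means these compounds.

Compound 3 `CC1(C)C[C@H](Nc2nc(NCc3cnccc3C(F)(F)F)ncc2C#N)CC[C@@H]1O` gives 6 nM in an assay on isolated protein for inhibition of protein kinase C theta type (Homo sapiens), read by TR-FRET, with a stated time of 2 h (on this read-out lower numbers stand for stronger inhibition and higher numbers for weaker inhibition), the lowest number of the three measured and clearly apart from compound 2 `N#Cc1cnc(NCc2cnccc2C(F)(F)F)cc1N[C@H]1CC[C@@H](c2nc[nH]n2)CC1`, which gives 34 nM, and from compound 1 `CO[C@H]1CC[C@@H](Nc2cc(NCc3cnccc3C(F)(F)F)ncc2C#N)CC1`, which gives 58 nM. The only step among these that alters a single place, a 1.7-fold lower number from compound 1 to compound 2 (0.23 log units; within the scatter), swaps groups on a saturated ring carbon and leaves the ring itself untouched. Compound 4 `CC1(C)[C@H](O)C[C@H]1Nc1nc(NCc2cnccc2C(F)(F)F)ncc1C#N` differs from compound 3 by 3-hydroxy-2,2-dimethylcyclobutyl in place of 4-hydroxy-3,3-dimethylcyclohexyl on a nitrogen on an aromatic ring. For the measured compounds named here, no measured pair shows a saturated ring of another size on this nitrogen, so the one recorded step gives no direct guide to the size of this change; it only shows that exchanging a substituent on that ring left the number within the scatter. With the core of compound 3 kept and only the saturated ring contracted, a modest rise in the number is expected, the step estimated as a 2.5-fold higher number from compound 3 to compound 4 (0.40 log units; beyond the scatter). Compound 4 is therefore estimated at 15 nM, with a range from 4 nM to 60 nM.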

Compound 4, half-maximal inhibitory concentration: 130 nM
Estimate against measurement, compound 4: 8.7-fold (0.94 log units) below; the measured number lies above the stated range.
By their numbers in this assay, from the lowest: compound 3; then compounds 2 and 1 (each within the scatter of the next); then compound 4.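

In this assay the saturated ring on this nitrogen proves to be a sensitive place: 3-hydroxy-2,2-dimethylcyclobutyl in place of 4-hydroxy-3,3-dimethylcyclohexyl gives a 22-fold higher number from compound 3 to compound 4 (1.34 log units; beyond the scatter) with the hydroxy and the two methyl groups still present. For the compounds shown here, the one earlier single-place step exchanged a substituent on a saturated ring and stayed within the scatter, so this is the first sign that changing the ring itself can move the number strongly. No supporting evidence bears on why the number rises.

The compounds shown do not separate the share of ring size from the share of where the hydroxy and dimethyl groups sit on the ring. They also leave open where a cyclopentyl ring carrying the same groups would fall, and whether an amine in place of the hydroxy group would be tolerated on either ring.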